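Extending the chain while swapping hydroxycarbamoyl for acetyl

The source may hold more compounds than are shown below. What is called first, only, known or untested is meant among the compounds shown, and "the series" means these compounds.

Compound 1 `Cn1cc(-c2ccc(=O)n(CCOc3ccnc4cc(OCCCC(=O)NO)ccc34)n2)cn1` gives 870 nM in a functional assay on EBC-1 cells (Homo sapiens) for antiproliferative activity, read by sulforhodamine B assay, with a stated time of 72 h (on this read-out lower numbers stand for stronger inhibition and higher numbers for weaker inhibition), the higher of the two numbers recorded, and sits a modest distance from compound 2 `Cn1cc(-c2ccc(=O)n(CCOc3ccnc4cc(OCCCCCCC(=O)NO)ccc34)n2)cn1`, which gives 210 nM. Among the compounds with values here, the only recorded step, a 4.1-fold lower number from compound 1 to compound 2 (0.62 log units; beyond the scatter), places a longer chain at the same position. Compound 3 `CC(=O)CCCCCOc1ccc2c(OCCn3nc(-c4cnn(C)c4)ccc3=O)ccnc2c1` differs from compound 1 by 2-acetylethyl in place of hydroxycarbamoyl on a saturated chain carbon, three bonds along the chain from an oxygen on an aromatic ring. Within the data shown here, the step from compound 1 to compound 2 shows only that a longer chain bearing the same hydroxycarbamoyl end gave a lower number; no measured pair shows what happens when hydroxycarbamoyl is removed altogether, so that step bears on compound 3 only in part. Without a step covering the loss of that group, compound 3 is expected to show a higher number, estimated as 3500 nM with a range of 900 nM to 14000 nM. The estimate implies a 4.0-fold higher number from compound 1 to compound 3 (0.60 log units; beyond the scatter) for compound 3.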

Compound 3, half-maximal inhibitory concentration: 25 nM
Compound 3: middle estimate off by 140-fold (2.15 log units), on the high side; measured number below the stated range.
By their numbers in this assay, from the lowest: compound 3; then compound 2; then compound 1.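

In this assay, a low number does not depend on hydroxycarbamoyl at this chain end: 5-acetylpentyl in place of 3-(hydroxycarbamoyl)propyl gives a 35-fold lower number from compound 1 to compound 3 (1.54 log units; beyond the scatter), a large step. The longer hydroxycarbamoyl chain is also passed, with an 8.4-fold lower number from compound 2 to compound 3 (0.92 log units; beyond the scatter), so the lowest of the three numbers belongs to the compound without that group. No evidence is available to explain this result at this position.

In both steps the end group and the chain length differ together, so the compounds shown do not separate what each contributes. They also leave open how a shorter chain ending in acetyl would read, and how a carboxylic acid, a primary amide or a plain alkyl chain with no carbonyl would compare at the same place.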